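The source may hold more compounds than are shown below. What is called first, only, known or untested is meant among the compounds shown, and "the series" means these compounds.

Measured so far:
compound 1 `CCC1C(=O)N(C)c2cnc(-n3ccc4cc(C(=O)NC(C)C)ccc43)nc2N1c1ccn(C)n1`: 12200 nM
compound 2 `CC[C@@H]1C(=O)N(C)c2cnc(-n3ccc4cc(C(=O)NC5CCCC5)ccc43)nc2N1C1CCCC1`: 856 nM

Both numbers come from a functional assay on NCI-H1975 cells (Homo sapiens) for antiproliferative activity, read by CCK-8 assay, with a stated time of 72 h; a lower number here means a stronger inhibitor of growth, a higher number a weaker inhibitor of growth. Compound 1 stands at the higher of the two, with compound 2 well below it, a gap beyond the usual scatter. The two differ in more than one place, so the pair shows only that gap and nothing about any single change. Compound 3 `CCCNC(=O)c1ccc2c(ccn2-c2ncc3c(n2)N(c2ccn(C)n2)C(CC)C(=O)N3C)c1` differs from compound 1 in one place: propyl in place of isopropyl on an amide-type nitrogen. Among the measured compounds shown here, no measured step of this kind exists in the set, so the change is expected to shift the number only a little, likely within the scatter. Compound 3 is therefore estimated at 10000 nM, range 4000 nM to 25000 nM, which means a step of a 1.2-fold lower number from compound 1 to compound 3 (0.09 log units; within the scatter).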

Compound 3, concentration for 50% growth inhibition: 11000 nM
Compound 3: middle estimate off by 1.1-fold (0.04 log units), on the low side, and the stated range covers the measured number.
By their numbers in this assay, from the lowest: compound 2; then compounds 3 and 1 (each within the scatter of the next).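

In this assay, among the compounds shown here, the change from isopropyl to propyl on the amide-type nitrogen gives a 1.1-fold lower number from compound 1 to compound 3 (0.04 log units; within the scatter) as the first step that can be read at a single place. With the rest of compound 1 held fixed, these two chains of 3 carbon atoms cannot be told apart at this position. No measurement at hand offers an explanation for this result.

Still open, on these data alone, is how a longer chain such as hexyl, or a chain ending in an amine or a carboxylic acid, would read on this nitrogen. Also open, as far as these compounds go, is whether the same change reads alike on the core of compound 2.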